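Cytotoxicity of a sugar-fused sulfonate series on HEL cells

This account rests on a few compounds, and the source may have more. Where it says the series, first, only, none or still open, it means among the compounds named here.

Compound 1, `Cc1cn([C@@H]2O[C@H](CO[Si](C)(C)C(C)(C)C)[C@@]3(OS(=O)(=O)C=C3NCC(=O)O)[C@H]2O[Si](C)(C)C(C)(C)C)c(=O)n(C)c1=O`: 136000 nM
Compound 2, `Cc1cn([C@@H]2O[C@H](CO[Si](C)(C)C(C)(C)C)[C@@]3(OS(=O)(=O)C=C3NCC(=O)C(=O)N3CCC3)[C@H]2O[Si](C)(C)C(C)(C)C)c(=O)n(C)c1=O`: 84400 nM
Compound 3, `CC(=O)NC1=CS(=O)(=O)O[C@@]12[C@@H](CO[Si](C)(C)C(C)(C)C)O[C@@H](n1cc(C)c(=O)n(C)c1=O)[C@@H]2O[Si](C)(C)C(C)(C)C`: > 200000 nM

Of the compounds shown here, three built on one shared core have been measured in a functional assay on HEL cells (Homo sapiens); a lower number here means that less compound is tolerated, a higher number that more compound is tolerated. Compound 2 stands lowest of the two numbers in this assay, with compound 1 nearest at a 1.6-fold lower number from compound 1 to compound 2 (0.21 log units; within the scatter), a gap within the scatter. Compound 3 returned only a limit of the assay, > 200000 nM, as noted in the limit of > 200000 nM in this assay, at which 1 of the 3 values shown sits.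

The next compound, compound 4, `COC(=O)C(=O)CNC1=CS(=O)(=O)O[C@@]12[C@@H](CO[Si](C)(C)C(C)(C)C)O[C@@H](n1cc(C)c(=O)n(C)c1=O)[C@@H]2O[Si](C)(C)C(C)(C)C`, departs from compound 2 at one position: methoxy in place of azetidin-1-yl on a carbonyl carbon. Among the measured compounds shown here, no measured step changes this same group, so the nearest guides are the steps that alter the chain on the amine nitrogen. Compound 1 to compound 2, a 1.6-fold lower number from compound 1 to compound 2 (0.21 log units; within the scatter), lay within the scatter. Compound 2 to compound 3, an at least 2.3-fold higher number from compound 2 to compound 3 (0.37 log units; beyond the scatter), reached beyond it but ended at a limit. Neither speaks to the exchange of azetidin-1-yl for methoxy itself, and both involve a larger reshaping of the chain than this one. The expectation is therefore a step of a 1.2-fold higher number from compound 2 to compound 4 (0.07 log units; within the scatter), close to the scatter and not clearly in either direction. Compound 4 is estimated at 100000 nM, within the range 50000 nM to 200000 nM.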

Compound 4, half-maximal cytotoxic concentration: > 200000 nM
Compound 4: a limit, no number (the forecaster's own chance of this, stated with the estimate: 15%); at least 2.0-fold (0.30 log units) between middle value and limit.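

In this assay, among the compounds shown here, methoxy in place of azetidin-1-yl on a carbonyl carbon gives an at least 2.3-fold higher number from compound 2 to compound 4 (0.37 log units; beyond the scatter), so this is the first measured sign that the group at the end of the chain can by itself move the number beyond the scatter, with the rest of the chain on the amine nitrogen unchanged. The comparison with the free acid is less informative, with an at least 1.4-fold higher number from compound 1 to compound 4 (0.16 log units; that floor lies within the scatter), and that floor does not separate methoxycarbonyl from hydroxy in place on this carbonyl carbon. Compound 4 gives > 200000 nM, a limit of the assay and not a number, so its step to compound 3, which also stands at a limit, cannot be read, and the series now gathers at one point: the limit of > 200000 nM in this assay, at which 2 of the 4 values shown sit.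

As far as these compounds go, it remains open how far compound 4 really lies from compound 2, and whether an ethoxy group or an open dimethylamino group on the same carbonyl carbon would fall with compound 2 or with compound 4. Whether the exchange of azetidin-1-yl for methoxy would give a similar step on a longer chain on the amine nitrogen is also left open.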